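Working notes: extending compound 2 at the amide-type nitrogen

The source may report more compounds than this note shows. Statements on the series, on what has been measured and on what is new or still open speak of the compounds shown alone.

Measured so far in a physicochemical assay for inhibition, read by spectrophotometry, with a stated time of 24 h, tested at 2.5 mM; on this read-out higher numbers stand for more inhibition at the one concentration tested (going by the name of the read-out) and lower numbers for less inhibition:
- compound 1, `O=C(CCN1CCN(c2ccnc3cc(Cl)ccc23)CC1)N/N=C/c1c[nH]c2ccccc12`: 43.3%
- compound 2, `NNC(=O)CCN1CCN(c2ccnc3cc(Cl)ccc23)CC1`: 21.7%

Compound 2 stands lowest of the two numbers in this assay; its nearest neighbour is compound 1, which sits higher by a step beyond the scatter. Going by the values given here, the only step measured within the pair is a number 21.6 percentage points lower from compound 1 to compound 2 (beyond the scatter), a modest loss when the larger group on the amide-type nitrogen is cut back to a single nitrogen atom.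

Compound 3, `O=C(CCN1CCN(c2ccnc3cc(Cl)ccc23)CC1)N/N=C/c1ccccc1O`, is not yet measured. It differs from compound 2 by a group of 9 heavy atoms (7 carbon, 1 nitrogen, 1 oxygen; one six-membered aromatic ring of carbon only) in place of one nitrogen atom, on an amide-type nitrogen. Among the compounds with values here, the change therefore runs in the same direction as the reverse of the one measured step, building out the same position from the bare nitrogen, though with a group of a different make-up and size than the one in compound 1. Within the data shown here, only that single step bears on the question, so the expectation rests on it alone.

On that basis compound 3 is expected to gain over compound 2 by about a number 18.3 percentage points higher from compound 2 to compound 3 (beyond the scatter) in this assay, a step beyond the scatter. Compound 3 is estimated at 40%, with a range of 25% to 55%.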

Compound 3, a percentage reported as inhibition, at one concentration (the size of the read-out at that concentration, not a potency): 83.2%
Beside the measured number, compound 3's estimate is 43.2 percentage points below it, and the stated range ends below it.
By their numbers in this assay, from the lowest: compound 2; then compound 1; then compound 3.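

In this assay, going by these compounds alone, building out the amide-type nitrogen can give far more than the one earlier step suggested: a number 61.5 percentage points higher from compound 2 to compound 3 (beyond the scatter), so the gain depends strongly on which group enters and not merely on replacing the amino group. The two extended compounds also separate clearly, with 2-hydroxyphenyl in place of 1H-indol-3-yl on the carbon with a double bond to nitrogen giving a number 39.9 percentage points higher from compound 1 to compound 3 (beyond the scatter), and here the group of 9 heavy atoms stands higher than the group of 11 heavy atoms, so among these three compounds the number does not simply follow the size of the entering group. No measurement in hand bears on the reason for either step.

The compounds shown leave open whether the gain belongs to the hydroxyl of 2-hydroxyphenyl or to the six-membered aromatic ring itself, a question that phenyl or 2-methoxyphenyl on the same carbon would address. Also open, as far as these compounds go, is whether the result holds with a longer chain joining the carbonyl to the shared core.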